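A few compounds are considered here, and "the series" means these few. Any claim that something is new, unique, unknown or untested is made for them only; others in the source may bear on it.

Compound 1 `CC1(c2ccccc2)CC(=O)C(C2CC(c3ccc(-c4ccc(Br)cc4)cc3)Cc3ccccc32)=C(O)O1` is the only one of the three measured compounds with a plain number: in a functional assay on SK-OV-3 cells (Homo sapiens) for inhibition, with a stated time of 72 h (on this read-out higher numbers stand for weaker inhibition and lower numbers for stronger inhibition), compound 1 gives 1800 nM. Compound 2 `CC1(c2ccccc2)CC(=O)C(C2CC(c3ccc(OCc4ccc(C(F)(F)F)cc4)cc3)Cc3ccccc32)=C(O)O1` reaches only a limit of the assay; in this assay compound 2 gives > 10000 nM. Compound 3 `CCC1(c2ccccc2)CC(=O)C(C2CC(c3ccc(-c4ccc(Br)cc4)cc3)Cc3ccccc32)=C(O)O1` also stops at a limit; in this assay compound 3 gives > 10000 nM. Compound 3 thus sits at the weak end of the numbers shown, at the limit of > 10000 nM in this assay, at which 2 of the 3 values shown sit. Compound 4 `CCC1(c2ccccc2)CC(=O)C(C2CC(c3ccc(OCc4ccc(C(F)(F)F)cc4)cc3)Cc3ccccc32)=C(O)O1` differs from compound 3 in one place: (4-(trifluoromethyl)benzyl)oxy in place of 4-bromophenyl on an aromatic carbon. The same change appears once already, as an at least 5.5-fold higher number from compound 1 to compound 2 (0.74 log units; beyond the scatter), and the change that produced compound 3, an at least 5.5-fold higher number from compound 1 to compound 3 (0.74 log units; beyond the scatter), pointed the same way; compound 4 carries both. A further loss is expected, estimated as a step that the limit leaves unreadable from compound 3 to compound 4. Compound 4 is therefore expected to give about 30000 nM, in the range 8000 nM to 150000 nM, most likely as a limit again.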

Compound 4, half-maximal inhibitory concentration: > 10000 nM
Compound 4: only a limit was reported; the forecaster's own chance of this, stated with the estimate: 90%; the middle value does not contradict the limit.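

Compound 4 also stops at a limit of this assay, so its steps from compound 2 and from compound 3 cannot be read. As far as these compounds go, how far compound 2, compound 3 and compound 4 lie past that limit stays open, and with it whether the two changes add up.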